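The compounds below may be only part of what the source reports. "The series", "measured", "known", "first", "only" and "open" are said of these compounds alone.

Compound 1 (`O=C(NCc1cc(Cl)ccc1-n1cnnn1)[C@@H]1CCNN1C(=O)[C@H](O)c1ccccc1`): 930 nM
Compound 2 (`O=C(NCc1cc(Cl)ccc1-n1cnnn1)[C@@H]1C[C@H]2C[C@H]2N1C(=O)[C@H](O)c1ccccc1`): 680 nM
Compound 3 (`CC1(C[C@@H](O)C(=O)N2C[C@H]3C[C@H]3[C@H]2C(=O)NCc2cc(Cl)ccc2-n2cnnn2)CC1`): 500 nM

All three numbers come from a functional assay on a cell-free system (plasma, Homo sapiens), with a stated time of 3 min (on this read-out lower numbers stand for stronger inhibition and higher numbers for weaker inhibition), and lie within the usual scatter of one another. Compound 2 reads 680 nM here, so its gaps to compound 3 (500 nM) and to compound 1 (930 nM) do not rank these compounds.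

Compound 4 (`CC(C)(C)[C@@H](O)C(=O)N1[C@@H]2C[C@@H]2C[C@H]1C(=O)NCc1cc(Cl)ccc1-n1cnnn1`) has not yet been measured. It differs from compound 2 in one place, with tert-butyl in place of phenyl on a saturated chain carbon bound to a carbonyl carbon and an oxygen on a saturated carbon.

Within the data shown here, no measured pair differs in only one place, so the data offer no direct guide to this change. The three measured compounds differ in structure yet stay within the scatter, so no step beyond the scatter is expected in this assay. The estimated step (a 1.2-fold lower number from compound 2 to compound 4 (0.09 log units; within the scatter)) is therefore small. For compound 4 the estimated value is 550 nM, with an expected range from 180 nM to 1700 nM, kept wide for want of a direct comparison.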

Compound 4, half-maximal inhibitory concentration: 1100 nM
Compound 4: middle estimate off by 2.0-fold (0.30 log units), on the low side, within the range that was stated.
By their numbers in this assay, from the lowest: compounds 3, 2, 1 and 4 (each within the scatter of the next, the first and the last beyond it).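

Among these compounds, this is the first comparison here in which only one place changes. In this assay, tert-butyl in place of phenyl on a saturated chain carbon bound to a carbonyl carbon and an oxygen on a saturated carbon gives a 1.6-fold higher number from compound 2 to compound 4 (0.21 log units; within the scatter), so on the core of compound 2 an aromatic ring at this position can be replaced by a group with no ring without a step beyond the scatter. Nothing measured here explains this result.

The compounds shown leave open whether an amine, a carboxylic acid or a longer chain such as n-butyl at this position would also stay within the scatter of compound 2. They also leave open whether the same swap would give a similar step on the core of compound 1.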